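Swapping the piperidine on the amide of a chemokine receptor binder

The source may hold more compounds than are shown below. What is called first, only, known or untested is meant among the compounds shown, and "the series" means these compounds.

Measured so far:
compound 1 `O=C(c1cccnc1)N1CCN(c2nccc(OCc3ccc(Cl)cc3Cl)n2)CC1`, > 10000 nM
compound 2 `CN1CCCC(C(=O)N2CCN(c3nccc(NCc4ccc(Cl)cc4Cl)n3)CC2)C1`, 700 nM

In an assay on HEK293 cells for displacement of a labelled ligand from C-C chemokine receptor type 4 (Homo sapiens) (a lower number here means a stronger inhibitor, a higher number a weaker inhibitor), compound 1 gives only a limit, > 10000 nM, which is the limit (the limit of > 10000 nM in this assay, at which 1 of the 2 values shown sits). Among the compounds with values here, compound 2 gives 700 nM in this assay, the only actual number so far. Compound 3 `O=C(C1CCNCC1)N1CCN(c2nccc(NCc3ccc(Cl)cc3Cl)n2)CC1` has not been measured. It differs from compound 2 by piperidin-4-yl in place of 1-methylpiperidin-3-yl on a carbonyl carbon. Within the data shown here, with no measured step to lean on, the change is expected to stay within the scatter or shift potency only modestly. For compound 3 the expected value in this assay is 700 nM, between 150 nM and 3000 nM, a step of no change at the digits printed from compound 2 to compound 3 (within the scatter).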

Compound 3, half-maximal inhibitory concentration: > 10000 nM
Compound 3: only a limit was reported; the forecaster's own chance of this, stated with the estimate: 10%; middle value at least 14-fold (1.15 log units) from the limit.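

So the group on the carbonyl carbon matters a great deal: a six-membered ring with one nitrogen does not suffice here, as piperidin-4-yl in place of 1-methylpiperidin-3-yl gives an at least 14-fold higher number from compound 2 to compound 3 (1.15 log units; beyond the scatter). In this assay, compound 3 gives only a limit, the same one as compound 1: the limit of > 10000 nM in this assay, at which 2 of the 3 values shown sit.

This change moves the ring's point of attachment and loses the methyl together, so the compounds shown cannot tell which of the two counts. 1-Methylpiperidin-4-yl and piperidin-3-yl, each carrying only one of these changes, would separate them.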